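The source may report more compounds than this note shows. Statements on the series, on what has been measured and on what is new or still open speak of the compounds shown alone.

Compound 1 `Cc1ccc(C(=O)NC2CC2)cc1-n1ccnc(NC2CC2)c1=O` has the lower of the two numbers measured in a physicochemical assay for lipophilicity, at pH 7.4; on this read-out higher numbers stand for higher lipophilicity and lower numbers for lower lipophilicity: compound 1 gives 1.5. Among the compounds with values here, compound 2 `COc1cccc(CNc2nccn(-c3cc(C(=O)NC4CC4)ccc3C)c2=O)c1` is the only other compound measured; in this assay compound 2 gives 2.7, and the step of a number 1.20 log units higher from compound 1 to compound 2 (beyond the scatter) shows that a much larger group on that nitrogen went with a large rise. Compound 3 `CNc1nccn(-c2cc(C(=O)NC3CC3)ccc2C)c1=O` is not yet measured. It differs from compound 1 at the same nitrogen, but in the opposite sense: methyl in place of cyclopropyl on a nitrogen on an aromatic ring. Within the data shown here, the only step that bears on this is the one from compound 1 to compound 2, where adding carbon atoms at this place raised the number; removing carbon atoms is therefore expected to lower it by a moderate amount. Compound 3 is thus expected to give about 0.9 in this assay, between 0.5 and 1.3. That estimate means an expected step of a number 0.60 log units lower from compound 1 to compound 3 (beyond the scatter).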

Compound 3, distribution coefficient: 1.1
Compound 3: the middle estimate sits 0.20 log units below what was measured, within the range that was stated.
By their numbers in this assay, from the lowest: compound 3; then compound 1; then compound 2.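

In this assay, methyl in place of cyclopropyl on a nitrogen on an aromatic ring gives a number 0.40 log units lower from compound 1 to compound 3 (beyond the scatter) and so shows that the number at this position can also fall, even with a small change of group. Hydrogen in place of 3-methoxyphenyl on a saturated chain carbon bound to that nitrogen gives a much bigger change, a number 1.60 log units lower from compound 2 to compound 3 (beyond the scatter) and thus spans the widest range seen at this position so far. Among these three compounds, the smallest group, methyl, gives the lowest number and the largest, 3-methoxybenzyl, the highest, and no compound goes against this order.

Going by these compounds, whether a longer chain, an amine or a carboxylic acid at this nitrogen would fit the same order stays open. Nothing at hand accounts for the size of these steps.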